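Larger Aryl Group at the Isoxazole Position of Compound 1

The source may report more compounds than this note shows. Statements on the series, on what has been measured and on what is new or still open speak of the compounds shown alone.

The measured compounds and their values:
compound 1, `CCCc1cc(-c2cn([C@H]3C[C@H](OC(C)=O)[C@@H](COC(C)=O)O3)c(=O)[nH]c2=O)on1`, 88.1%
compound 2, `CC(=O)OC[C@H]1O[C@@H](n2cc(-c3cn(Cc4ccccc4)nn3)c(=O)[nH]c2=O)C[C@@H]1OC(C)=O`, 92.1%
compound 3, `CCCCCCCCc1cc(-c2cn([C@H]3C[C@H](O)[C@@H](CO)O3)c(=O)[nH]c2=O)on1`, 77.3%

In a functional assay on PC-3 cells (Homo sapiens) for cytotoxicity, read by sulforhodamine B assay, tested at 10 uM (a higher number here means more inhibition at the concentration tested (going by the name of the read-out), a lower number less inhibition), compound 1 stands second highest of the three numbers. Compound 2 gives a value within the scatter of it, so no order between the two can be claimed, while compound 3 gives a value that lies beyond the scatter below compound 1.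

Compound 4 is `CCCCc1ccc(-c2cc(-c3cn([C@H]4C[C@H](OC(C)=O)[C@@H](COC(C)=O)O4)c(=O)[nH]c3=O)on2)cc1`. It differs from compound 1 in one place: 4-butylphenyl in place of propyl on an aromatic carbon.

Within the data shown here, no step between measured compounds matches this change, so the expectation rests on the three numbers alone. All lie high, and the larger group in compound 3 goes with the lowest one. For compound 4 the step of a number 4.1 percentage points lower from compound 1 to compound 4 (within the scatter) is expected to stay within the scatter, leaning slightly downward. Compound 4 is therefore estimated at 84%, between 65% and 95%.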

Compound 4, a percentage reported as inhibition, at one concentration (the size of the read-out at that concentration, not a potency): 30.4%
Estimate against measurement, compound 4: 53.6 percentage points above; the measured number lies below the stated range.
By their numbers in this assay, from the lowest: compound 4; then compound 3; then compounds 1 and 2 (each within the scatter of the next).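

In this assay, putting 4-butylphenyl in place of propyl on this aromatic carbon gives a number 57.7 percentage points lower from compound 1 to compound 4 (beyond the scatter). Among these compounds, this is the first single-place comparison, and it shows that the number at this position can depend strongly on the group placed there. Nothing measured here bears on the reason for this drop.

Still open, from the compounds shown here alone, is whether the loss goes with the six-membered aromatic ring itself or with the butyl chain on it. A plain phenyl group on the same carbon of compound 1 would separate the two.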